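Swapping the isopropylpiperidine of compound 2 for a smaller oxygen ring

The source may report more compounds than this note shows. Statements on the series, on what has been measured and on what is new or still open speak of the compounds shown alone.

Compound 2 `Cc1cc(C)c(S(=O)(=O)N2CCC(N3CCC(C(C)C)CC3)CC2)c(C)c1` stands lowest of the three measured compounds in a functional assay on DLD-1 cells (Homo sapiens) for antiproliferative activity, read by CellTiter-Glo, with a stated time of 72 h (on this read-out lower numbers stand for stronger inhibition and higher numbers for weaker inhibition), at 0.3 nM. Compound 1 `Cc1cc(C)c(S(=O)(=O)N2CCC(N3CCC(Cc4ccc(F)cc4)CC3)CC2)c(C)c1` gives 18 nM in this assay, and compound 3 `Cc1cc(C)c(S(=O)(=O)N2CCC(N3CCC(Cc4ccccc4F)CC3)CC2)c(C)c1` gives 74 nM. Compound 4 `Cc1cc(C)c(S(=O)(=O)N2CCC(N3CCC(C)OC3)CC2)c(C)c1` differs from compound 2 by a group of 7 heavy atoms (5 carbon, 1 nitrogen, 1 oxygen; one six-membered non-aromatic ring with 2 hetero atoms) in place of a group of 9 heavy atoms (8 carbon, 1 nitrogen; one six-membered non-aromatic ring with 1 hetero atom), on a saturated ring carbon. Within the data shown here, no measured step exchanges the whole ring; the nearest steps change only the isopropyl on that ring, and both went strongly upward: a 60-fold lower number from compound 1 to compound 2 (1.78 log units; beyond the scatter) and a 250-fold higher number from compound 2 to compound 3 (2.39 log units; beyond the scatter), whereas a 4.1-fold higher number from compound 1 to compound 3 (0.61 log units; beyond the scatter) was modest. Since every departure from the isopropyl seen so far raised the number sharply, a clearly higher number is expected for compound 4, a 100-fold higher number from compound 2 to compound 4 (2.00 log units; beyond the scatter). Compound 4 is estimated at 30 nM, with a range from 3 nM to 300 nM.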

Compound 4, half-maximal inhibitory concentration: 92 nM
Beside the measured number, compound 4's estimate is 3.1-fold (0.49 log units) below it, and the stated range covers the measured number.
By their numbers in this assay, from the lowest: compound 2; then compound 1; then compounds 3 and 4 (each within the scatter of the next).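

Earlier steps changed only the isopropyl, whereas this one replaces the whole 4-isopropylpiperidin-1-yl group, and in this assay it is large, a 310-fold higher number from compound 2 to compound 4 (2.49 log units; beyond the scatter). The low number of compound 2 is therefore lost not only with the benzyl groups of compound 1 and compound 3, but also with a group of fewer heavy atoms that holds a ring oxygen. Nothing available explains this loss.

On these data alone, it remains open whether the ring oxygen or the loss of the isopropyl matters more, which a piperidine carrying only a methyl could separate. Also open, as far as these compounds go, is whether a cyclopropyl or tert-butyl in the isopropyl's place would keep the low number.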